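Ester-to-amide switch on the pyrrole carbonyl of compound 3

The source may hold more compounds than are shown below. What is called first, only, known or untested is meant among the compounds shown, and "the series" means these compounds.

Measured so far:
compound 1 `CC(=O)NCCCCNC(=O)c1[nH]cc(C(=O)OC2CC3CCC2C3)c1C` gives 200 nM in an assay on CHO cells for inhibition of metabotropic glutamate receptor 1 (Homo sapiens); a higher number here means a weaker inhibitor, a lower number a stronger inhibitor
compound 2 `CCCOC(=O)c1[nH]cc(C(=O)O[C@@H](C)C(C)(C)C)c1C` gives 3.98 nM in this assay
compound 3 `CCOC(=O)c1[nH]c(C)c(C(=O)OC2CC3CCC2C3)c1C` gives 100 nM in this assay

Compound 3 stands second highest of the three numbers. Compound 1 lies within the scatter of it, so no order between compound 1 and compound 3 is claimed; compound 2 sits far lower, a gap beyond the scatter. Compound 4 `COCCNC(=O)c1[nH]c(C)c(C(=O)OC2CC3CCC2C3)c1C` is not yet measured. It differs from compound 3 by (2-methoxyethyl)amino in place of ethoxy on a carbonyl carbon. Within the data shown here, no measured pair shows this exact change. Compound 1, which also carries an amide at that carbonyl, gives 200 nM, so an amide at this position is tolerated. The expected step from compound 3 to compound 4 is a 1.5-fold higher number from compound 3 to compound 4 (0.18 log units; within the scatter), not beyond the scatter. Compound 4 is therefore estimated at 150 nM, within 40 nM to 600 nM.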

Compound 4, half-maximal inhibitory concentration: 316 nM
Estimate against measurement, compound 4: 2.1-fold (0.32 log units) below, within the range that was stated.
By their numbers in this assay, from the lowest: compound 2; then compounds 3, 1 and 4 (each within the scatter of the next, the first and the last beyond it).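

Among these compounds, putting (2-methoxyethyl)amino in place of ethoxy on a carbonyl carbon gives a 3.2-fold higher number from compound 3 to compound 4 (0.50 log units; beyond the scatter) in this assay and provides the first reading of this change in which only one place differs. The switch from ester to this amide therefore weakens inhibition here, a loss that the amide of compound 1, which differs from compound 3 in more than one place, could not isolate. No measurement on hand explains the step.

On these data alone, whether the loss follows the amide hydrogen or the chain remains open. An ethylamino group, a dimethylamino group or a carboxylic acid on this carbonyl would test that.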